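A few compounds are considered here, and "the series" means these few. Any claim that something is new, unique, unknown or untested is made for them only; others in the source may bear on it.

Measured so far in an assay on isolated protein for inhibition of Amine oxidase [flavin-containing] A (Homo sapiens), read by fluorescence, with stated times of 15 min and 20 min; a lower number here means a stronger inhibitor, a higher number a weaker inhibitor:
compound 1 `O=C(CBr)N1N=C(c2ccc(F)cc2)CC1c1ccccc1O`: 6000 nM
compound 2 `O=C(CN1CCCCC1)N1N=C(c2ccccc2)CC1c1ccccc1O`: 9510 nM
compound 3 `COc1ccc(C2=NN(C(=O)CN3CCCCC3)C(c3cc(Cl)ccc3O)C2)cc1`: 9650 nM

Compound 1 gives the lowest number of the three, but its gaps to compound 2 and to compound 3 both lie within the scatter, so no order can be read among them. Compound 4 `O=C(Cn1ccnc1)N1N=C(c2ccc(F)cc2)CC1c1ccccc1O` is not yet measured. It differs from compound 1 by 1H-imidazol-1-yl in place of bromo on a saturated chain carbon bound to a carbonyl carbon. Among the measured compounds shown here, no pair of measured compounds isolates this change, so nothing measured tells its size. Compound 2 at 9510 nM and compound 3 at 9650 nM sit in the same span as compound 1, so in this assay only a small step is expected, if anything toward a higher number, not clearly beyond the scatter. The expected step is a 1.5-fold higher number from compound 1 to compound 4 (0.18 log units; within the scatter). For compound 4 the estimate is 9000 nM, within 3000 nM to 27000 nM.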

Compound 4, half-maximal inhibitory concentration: 26300 nM
Estimate against measurement, compound 4: 2.9-fold (0.47 log units) below, within the range that was stated.
By their numbers in this assay, from the lowest: compounds 1, 2 and 3 (each within the scatter of the next); then compound 4.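

In this assay, the position on a saturated chain carbon bound to a carbonyl carbon proves sensitive to its substituent: 1H-imidazol-1-yl in place of bromo gives a 4.4-fold higher number from compound 1 to compound 4 (0.64 log units; beyond the scatter) and so separates two compounds beyond the scatter, which no earlier comparison could do. On the core of compound 1, bromo therefore holds the lower number of the two groups. No evidence at hand accounts for this step.

Still open, on these data alone, is whether a simple amine such as dimethylamino or a carboxylic acid at this position would stay close to compound 1 or move as compound 4 does. Compounds 2 and 3 differ from compound 1 in more than one place, so their steps cannot be read.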